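This account rests on a few compounds, and the source may have more. Where it says the series, first, only, none or still open, it means among the compounds named here.

compound 1 `Cc1nc2ccccc2nc1Oc1ccc(C(=O)N[C@@H](C)C(=O)O)cc1`: 22300 nM
compound 2 `CCCCCCCCCCCCNc1nc2ccccc2nc1Oc1ccc(C(=O)N[C@@H](C)C(=O)O)cc1`: 6240 nM

In a functional assay on HeLa cells (Homo sapiens) for antiproliferative activity, read by MTT assay, with a stated time of 48 h (a lower number here means a stronger inhibitor, a higher number a weaker inhibitor), compound 2 has the lower of the two numbers, 6240 nM, which makes it the stronger inhibitor of the pair. Compound 1 stands at 22300 nM, and this gap lies beyond the usual scatter. Compound 3 `C[C@H](NC(=O)c1ccc(Oc2nc3ccccc3nc2NC(C)(C)C)cc1)C(=O)O` keeps the shared core and changes one group, with tert-butyl in place of dodecyl on a nitrogen on an aromatic ring. Among the compounds with values here, no measured pair isolates this change, so any forecast is loose. Compound 1, which has no dodecyl group, gives 22300 nM, so compound 3 is expected to give up part of the lead held by compound 2. The expected change is a modest rise in the number, a 2.1-fold higher number from compound 2 to compound 3 (0.32 log units; beyond the scatter). For compound 3 the estimated value is 13000 nM, with an expected range from 4500 nM to 35000 nM.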

Compound 3, half-maximal inhibitory concentration: 23400 nM
For compound 3 the middle estimate is 1.8-fold (0.26 log units) below the measured one, within the range that was stated.
By their numbers in this assay, from the lowest: compound 2; then compounds 1 and 3 (each within the scatter of the next).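

Replacing dodecyl with tert-butyl on a nitrogen on an aromatic ring gives a 3.8-fold higher number from compound 2 to compound 3 (0.57 log units; beyond the scatter) in this assay and so removes the lead that compound 2 held. Putting (tert-butyl)amino in place of methyl on an aromatic carbon gives a 1.0-fold higher number from compound 1 to compound 3 (0.02 log units; within the scatter) and so separates compound 3 from compound 1 by nothing beyond the scatter, which means that a substituted nitrogen at this place does not by itself match compound 2. Nothing available explains these differences in cell activity.

From the compounds shown here alone, whether the lower number needs the full dodecyl chain, or whether a shorter straight chain such as hexyl or octyl on the same nitrogen would keep it, stays open. Going by these compounds, it is also open where a plain unsubstituted amine at this place would fall.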